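Fluoro on the second phenyl of a cytotoxic indole core

The source may report more compounds than this note shows. Statements on the series, on what has been measured and on what is new or still open speak of the compounds shown alone.

Compound 1, `CC(=O)c1cc(-c2ccccc2)cc2cc(-c3ccccc3)[nH]c12`, stands highest of the two numbers in a functional assay on MCF7 cells (Homo sapiens) for cytotoxicity, read by MTT assay, with a stated time of 2 days, tested at 1 uM (on this read-out higher numbers stand for a weaker effect at the one concentration tested and lower numbers for a stronger effect), giving 98.6%. Its nearest neighbour is compound 2, `CC(=O)c1cc(-c2ccc(F)cc2)cc2cc(-c3ccccc3)[nH]c12`, which in this assay gives 82.7%, a step of a number 15.9 percentage points lower from compound 1 to compound 2 (beyond the scatter) that lies beyond the scatter. Compound 3, `CC(=O)c1cc(-c2ccccc2)cc2cc(-c3ccc(F)cc3)[nH]c12`, is not yet measured; it differs from compound 1 by fluoro in place of hydrogen on an aromatic carbon, the fluoro now sitting on the other phenyl of the shared core. Among the measured compounds shown here, the only step that bears on it is the one from compound 1 to compound 2, where the same change on the first phenyl lowered the number by a modest amount. A step of similar size and direction, or a smaller one within the scatter, is therefore expected, namely a number 10.6 percentage points lower from compound 1 to compound 3 (beyond the scatter). Compound 3 is estimated to give 88% in this assay, within a range of 72% to 100%.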

Compound 3, a percentage reported as activity, at one concentration (the size of the read-out at that concentration, not a potency): 96.8%
For compound 3 the middle estimate is 8.8 percentage points below the measured one, and the stated range covers the measured number.
By their numbers in this assay, from the lowest: compound 2; then compounds 3 and 1 (each within the scatter of the next).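

In this assay, the phenyl to 4-fluorophenyl change on this ring gives a number 1.8 percentage points lower from compound 1 to compound 3 (within the scatter) and so registers no change, whereas the same change on the other phenyl gave a number 15.9 percentage points lower from compound 1 to compound 2 (beyond the scatter). Across these three compounds, the outcome of adding this fluoro therefore depends on which phenyl of the shared core carries it, and only the step to compound 2 lies beyond the scatter. Nothing in the available data explains why the two phenyl rings differ in this way.

Going by these compounds, it remains open whether a chloro, a methoxy or an amine in the same place would also leave the number within the scatter of compound 1. Also open, on these data alone, is how a fluoro on both phenyl rings of the shared core would read at this single concentration.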